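The source may report more compounds than this note shows. Statements on the series, on what has been measured and on what is new or still open speak of the compounds shown alone.

Compound 1, `COc1cc(C2CC(c3ccc(OCc4cn(Cc5ccc([N+](=O)[O-])cc5)nn4)cc3)=NN2C(C)=O)ccc1Oc1cn(Cc2ccc([N+](=O)[O-])cc2)nn1`, gives in a functional assay on THP-1 cells (Homo sapiens) for inhibition, read by sulforhodamine B assay, tested at 100 uM (on this read-out higher numbers stand for more inhibition of growth at the one concentration tested and lower numbers for less inhibition of growth), a value of 15%.
Compound 2, `COc1ccc(C2CC(c3ccc(OCc4cn(Cc5ccc([N+](=O)[O-])cc5)nn4)cc3)=NN2C(C)=O)cc1`, gives in this assay a value of 26%.
Compound 3, `COc1cc(C2CC(c3ccc(Br)cc3)=NN2C(C)=O)ccc1OCc1cn(Cc2ccc([N+](=O)[O-])cc2)nn1`, gives in this assay a value of 23%.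

All three were tested at a single concentration, so each number tells only how far that compound slowed the growth of the cells in the dish. Compound 3 stands second highest of the three numbers. Its nearest neighbour is compound 2, a little higher, and the furthest is compound 1, somewhat lower; both gaps lie within the usual scatter of repeated measurements, so on these data the three compounds cannot be told apart.

Compound 4, `COc1cc(C2CC(c3cc(OC)c(OC)c(OC)c3)=NN2C(C)=O)ccc1OCc1cn(Cc2ccc([N+](=O)[O-])cc2)nn1`, has not been measured. It differs from compound 3 in one place: 3,4,5-trimethoxyphenyl in place of 4-bromophenyl on a carbon with a double bond to nitrogen. Among the measured compounds shown here, no pair of measured compounds differs by this change, so nothing in the numbers above points up or down for it. The step of a number 2 percentage points higher from compound 3 to compound 4 (within the scatter) is therefore expected to stay within the scatter rather than go beyond it. Compound 4 is expected to give about 25% in this assay, with an expected range from 10% to 45%.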

Compound 4, percent growth inhibition at one concentration: 43%
For compound 4 the middle estimate is 18 percentage points below the measured one, within the range that was stated.
By their numbers in this assay, from the lowest: compounds 1, 3 and 2 (each within the scatter of the next, the first and the last beyond it); then compound 4.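

In this assay, among the compounds shown here, putting 3,4,5-trimethoxyphenyl in place of 4-bromophenyl on the carbon with a double bond to nitrogen gives a number 20 percentage points higher from compound 3 to compound 4 (beyond the scatter), the only step here between two compounds that differ in one place. For the compounds shown here, this shows that the group at this position matters: with the rest of the molecule unchanged, the change alters how far growth is inhibited at the one concentration tested, whereas the earlier compounds offered no such direct comparison. The change removes a bromine and brings in three methoxy groups together, so the step belongs to the whole swap of one aryl group for the other, and no evidence here explains why the number goes up.

The compounds shown leave open whether a single methoxy group on the phenyl ring would give a similar step, or whether all three are needed, and how a phenyl ring carrying an amine or a carboxylic acid would behave at this position. They also leave open whether the same swap would give a similar step with the other side of the molecule changed, for instance in the setting of compound 2.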